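A few compounds are considered here, and "the series" means these few. Any claim that something is new, unique, unknown or untested is made for them only; others in the source may bear on it.

Of the compounds shown here, three have been measured in a functional assay on RKO cells (Homo sapiens) for cytotoxicity, read by MTT assay, with a stated time of 48 h; a higher number here means a weaker inhibitor, a lower number a stronger inhibitor. Compound 1 `CCOc1ccc2c(NCCCN(C)C)ccnc2c1` gives 5240 nM, compound 2 `CCCCCCOc1ccc2c(NCCN(C)C)ccnc2c1` gives 1120 nM, and compound 3 `CCOc1ccc2c(NCCN(C)C)ccnc2c1` gives 3650 nM. Compound 3 thus holds the second highest number of the three, nearest to compound 1 and furthest from compound 2. The step of a 1.4-fold lower number from compound 1 to compound 3 (0.16 log units; within the scatter) carries little; the step of a 3.3-fold higher number from compound 2 to compound 3 (0.51 log units; beyond the scatter) is the one that matters here, as it concerns the chain on the oxygen on the aromatic ring. Compound 4 `CN(C)CCNc1ccnc2cc(OCc3ccccc3)ccc12` differs from compound 3 by phenyl in place of methyl on a saturated chain carbon bound to an oxygen on an aromatic ring. Since compound 2 with its longer chain gives 1120 nM, a modest drop in number is expected. Compound 4 is expected at 1500 nM in this assay, within 600 nM to 3800 nM. The estimated step is a 2.4-fold lower number from compound 3 to compound 4 (0.39 log units; beyond the scatter).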

Compound 4, half-maximal inhibitory concentration: 2350 nM
For compound 4 the middle estimate is 1.6-fold (0.19 log units) below the measured one, and the stated range covers the measured number.
By their numbers in this assay, from the lowest: compound 2; then compounds 4, 3 and 1 (each within the scatter of the next, the first and the last beyond it).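

On the saturated chain carbon bound to an oxygen on an aromatic ring, phenyl in place of methyl gives a 1.6-fold lower number from compound 3 to compound 4 (0.19 log units; within the scatter), so benzyloxy and ethoxy are not separated in this assay. Phenyl in place of pentyl gives a 2.1-fold higher number from compound 2 to compound 4 (0.32 log units; beyond the scatter), so at this place the open chain of compound 2 keeps the lower number and the added ring does not match it. No evidence bearing on the reason for this difference is at hand. Going by these compounds, whether a chain longer than that of compound 2, or a benzyl ring carrying a chlorine or a methoxy group, would shift the number further stays open.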